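This account rests on a few compounds, and the source may have more. Where it says the series, first, only, none or still open, it means among the compounds named here.

Measured in a functional assay on MCF7 cells (Homo sapiens) for antiproliferative activity, read by MTT assay, with a stated time of 48 h; a lower number here means a stronger inhibitor, a higher number a weaker inhibitor:
- compound 1 `Clc1ccc(-c2nn(-c3ccccc3)cc2-c2nc3cc(Cl)ccc3[nH]2)cc1`: 1170 nM
- compound 2 `COc1ccc2[nH]c(-c3cn(-c4ccccc4)nc3-c3ccc(Cl)cc3)nc2c1`: 1760 nM
- compound 3 `FC(F)(F)c1ccc2[nH]c(-c3cn(-c4ccccc4)nc3-c3ccc(Cl)cc3)nc2c1`: 4210 nM

Of these three numbers, the highest belongs to compound 3, at 4210 nM. The steps leading to that number are a 3.6-fold higher number from compound 1 to compound 3 (0.56 log units; beyond the scatter) and a 2.4-fold higher number from compound 2 to compound 3 (0.38 log units; beyond the scatter), both modest. The remaining step, a 1.5-fold higher number from compound 1 to compound 2 (0.18 log units; within the scatter), lies within the scatter.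

The next comparison is with compound 4 `O=C(OCc1ccccc1)c1ccc2[nH]c(-c3cn(-c4ccccc4)nc3-c3ccc(Cl)cc3)nc2c1`. The change is benzyloxycarbonyl in place of trifluoromethyl on an aromatic carbon.

Among the compounds with values here, all three measured steps are swaps of one group on an aromatic carbon, so they are the only guide here, and none exceeds a modest size. None of them involves benzyloxycarbonyl, so the data give no direct reading of this group, and the uncertainty is wide in both directions. Compound 3 sits at the top of the small measured range, so a move back towards the other two values is the more likely outcome in this assay. The expected change is modest and towards a lower number, estimated as a 1.7-fold lower number from compound 3 to compound 4 (0.23 log units; within the scatter). For compound 4 the estimated value is 2500 nM, with an expected range from 800 nM to 8000 nM.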

Compound 4, half-maximal inhibitory concentration: 13900 nM
Compound 4: middle estimate off by 5.6-fold (0.75 log units), on the low side; measured number above the stated range.
By their numbers in this assay, from the lowest: compounds 1 and 2 (each within the scatter of the next); then compound 3; then compound 4.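

In this assay, within the data shown here, benzyloxycarbonyl on this aromatic carbon gives the weakest compound of the four: a 3.3-fold higher number from compound 3 to compound 4 (0.52 log units; beyond the scatter), a 7.9-fold higher number from compound 2 to compound 4 (0.90 log units; beyond the scatter) and a 12-fold higher number from compound 1 to compound 4 (1.07 log units; beyond the scatter), the last being the only step in the set printed as large. The earlier swaps among chloro, methoxy and trifluoromethyl stayed modest or within the scatter, whereas compound 4 shows that a change at this place can move the number further, here with a larger group that adds a six-membered aromatic ring and two hydrogen-bond acceptors. No measurement shown here accounts for this loss, and this single change cannot separate the contributions of the added ring, the carbonyl and the overall size of the group.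

On these data alone, it remains open which part of benzyloxycarbonyl goes with the higher number, a question that a carboxylic acid, a methyl ester or an amide at this place could help to answer. Also open, as far as these compounds go, is whether any group here can give a number lower than those of compound 1 and compound 2, for instance an amine or a smaller halogen such as fluoro.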